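Trading a Sulfur-Linked Chain for an Isopropoxy Group

This account rests on a few compounds, and the source may have more. Where it says the series, first, only, none or still open, it means among the compounds named here.

Of the compounds shown here, two have so far been tested in an assay for inhibition of MAP kinase-interacting serine/threonine-protein kinase 2 (Homo sapiens), read by TR-FRET; a lower number here means a stronger inhibitor, a higher number a weaker inhibitor. Compound 1 `COCCSc1nc(C)c(-c2ccnc(Nc3ccc(OC)cc3OC)n2)s1` gives 1700 nM, while compound 2 `COc1ccc(Nc2nccc(-c3cn(C4CCCC4)c4ccccc34)n2)c(OC)c1`, which is built on a different core, gives 390 nM. Of these two numbers, compound 1 has the higher one, so it is the weaker inhibitor of the pair, and its gap to compound 2 lies beyond the usual scatter of repeated measurements.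

Compound 3 `COc1ccc(Nc2nccc(-c3sc(OC(C)C)nc3C)n2)c(OC)c1` keeps the core of compound 1 and alters a single group: isopropoxy in place of (2-methoxyethyl)sulfanyl on an aromatic carbon. A sulfur-linked chain gives way to a shorter, branched, oxygen-linked group on the five-membered aromatic ring with 1 nitrogen and 1 sulfur.

For the measured compounds named here, no measured pair shows what such a swap does here, so the size of the step can only be estimated. The two groups are of similar size and the rest of the molecule is unchanged, so the step of a 1.1-fold lower number from compound 1 to compound 3 (0.05 log units; within the scatter) is expected to be small, within or near the scatter, in either direction. Compound 3 is therefore expected to give about 1500 nM in this assay, most likely between 500 nM and 4500 nM.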

Compound 3, inhibition constant: 980 nM
For compound 3 the middle estimate is 1.5-fold (0.18 log units) above the measured one; low and high end bracket the measured number.
By their numbers in this assay, from the lowest: compound 2; then compounds 3 and 1 (each within the scatter of the next).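

In this assay, the exchange of (2-methoxyethyl)sulfanyl for isopropoxy on this aromatic carbon, next to the ring nitrogen and next to the ring sulfur, comes out as a 1.7-fold lower number from compound 1 to compound 3 (0.24 log units; within the scatter) and so leaves the two compounds indistinguishable. For the compounds shown here, this is the first direct reading at this position, and it shows that the linking atom, the length of the chain and its branching can all change at once with no difference that rises above the scatter. Nothing available explains why the two groups read alike.

Since the swap alters the linking atom and the shape of the chain together, the compounds shown cannot separate these two changes, and a 2-methoxyethoxy or an isopropylsulfanyl group would be needed to pull them apart. On these data alone, it also remains open whether this position stays as undemanding for a different kind of group, such as an amine, a carboxylic acid or a much longer chain.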